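The source may report more compounds than this note shows. Statements on the series, on what has been measured and on what is new or still open speak of the compounds shown alone.

Among compounds tested in a functional assay on the whole organism (stomach) with Rattus norvegicus as the target (on this read-out lower numbers stand for an effect already at smaller amounts and higher numbers for an effect only at larger amounts of compound), three have numbers so far. Compound 1 `Cc1ccc(=S)n(CCC(=N)S)n1` gives 100 mg/kg in this assay. Compound 2 `N=C(S)CCCCCCN1N=C(c2ccccc2)CCC1=O` gives 58.8 mg/kg in this assay, the second highest of the three numbers; its nearest neighbour is compound 1, whose number lies within the scatter of it, and furthest from it is compound 3 `N=C(S)CCCCCn1nc(-c2ccccc2)ccc1=O`, which gives 23.3 mg/kg in this assay, a gap beyond the scatter.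

Compound 4 `N=C(S)CCCCCN1N=C(c2ccccc2)CCC1=O` has not yet been measured in this assay. It differs from compound 2 in one place: a group of 3 heavy atoms (1 carbon, 1 nitrogen, 1 sulfur; no ring) in place of a group of 4 heavy atoms (2 carbon, 1 nitrogen, 1 sulfur; no ring), on a saturated chain carbon, five bonds along the chain from an amide-type nitrogen in a ring. Among the measured compounds shown here, no step between two measured compounds shares this change, so its size has to be guessed. For the measured compounds named here, the only point of comparison is compound 3, which carries a chain of the same length as compound 4 but sits on a different core, and its number in this assay lies beyond the scatter below that of compound 2. On that thin basis the step from compound 2 to compound 4 in this assay is expected to be small, a 1.3-fold lower number from compound 2 to compound 4 (0.12 log units; within the scatter), most likely towards a lower number but not clearly beyond the scatter. Compound 4 is estimated to give 45 mg/kg in this assay, with a range from 20 mg/kg to 110 mg/kg.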

Compound 4, dose for half-maximal effect: 100 mg/kg
The estimate for compound 4 lay 2.2-fold (0.35 log units) below the measured number; the measured number falls inside the stated range.
By their numbers in this assay, from the lowest: compound 3; then compounds 2, 1 and 4 (each within the scatter of the next).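

Among the compounds shown here, at this place on the chain, the first readable step in this assay comes from the group of 3 heavy atoms in place of the group of 4 heavy atoms, on a saturated chain carbon, five bonds along the chain from an amide-type nitrogen in a ring, and it amounts to a 1.7-fold higher number from compound 2 to compound 4 (0.23 log units; within the scatter) on the shared core, so this change does not separate the two compounds on this read-out. Compound 3 carries the same chain as compound 4, yet compound 3 gives 23.3 mg/kg in this read-out while compound 4 gives 100 mg/kg there, which shows that this chain does not by itself go with the lowest number of the set. Nothing at hand speaks to what lies behind this result.

The compounds shown leave open whether a longer chain on this core would stay within the scatter of compound 2 or move beyond it, and whether the same change would give a step of similar size on the core of compound 3. They also leave open what an amine or a carboxylic acid would do in place of these groups on the same saturated chain carbon.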